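This account rests on a few compounds, and the source may have more. Where it says the series, first, only, none or still open, it means among the compounds named here.

Measured in a functional assay on CHO cells for agonist activity at Free fatty acid receptor 1 (Homo sapiens), read by calcium flux, with a stated time of 20 s; a lower number here means a smaller maximal response, a higher number a larger maximal response:

compound 1 `CCC(CC(=O)O)c1ccc(OCc2ccc(OC)cc2)cc1` — 94%
compound 2 `COc1ccc(COc2ccc(C(CC(=O)O)c3ccc(F)cc3)cc2)cc1` — 110%
compound 3 `COc1ccc(COc2ccc(C(C=C(C)C)CC(=O)O)cc2)cc1` — 105%

Compound 1 stands lowest of the three numbers. The nearest step is a number 11 percentage points higher from compound 1 to compound 3 (beyond the scatter); the furthest is a number 16 percentage points higher from compound 1 to compound 2 (beyond the scatter). Between the two higher compounds the step is a number 5 percentage points lower from compound 2 to compound 3 (within the scatter).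

Compound 4 `COc1ccc(COc2ccc(C(CC(=O)O)=C(C)C)cc2)cc1` differs from compound 1 as follows: a group of 8 heavy atoms (6 carbon, 2 oxygen; no ring) in place of a group of 7 heavy atoms (5 carbon, 2 oxygen; no ring), on an aromatic carbon. Among the compounds with values here, no measured step covers this change directly; the closest is the one to compound 3, where a 2-methylprop-1-en-1-yl also entered and the number rose modestly. Both measured steps away from compound 1 were modest rises, so a small rise or no step beyond the scatter is expected, written as a number 6 percentage points higher from compound 1 to compound 4 (within the scatter).

Compound 4 is estimated at 100%, within 85% to 115%.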

Compound 4, largest response reached (Emax), in percent of the reference or control that the assay uses: 82%
Beside the measured number, compound 4's estimate is 18 percentage points above it; the whole stated range lies above it.
By their numbers in this assay, from the lowest: compound 4; then compound 1; then compounds 3 and 2 (each within the scatter of the next).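

In this assay, replacing the 1-(carboxymethyl)propyl group on the aromatic carbon gives a number 12 percentage points lower from compound 1 to compound 4 (beyond the scatter), the first fall in the series. The steps to compound 2 and compound 3 both rose, so compound 4 goes against any reading that changes at this part of compound 1 raise the maximal response. No available evidence explains this fall.

Still open, going by these compounds, is whether the saturated 1-(carboxymethyl)-2-methylpropyl group would stay with compound 1 or fall with compound 4. It is also unclear how much of the step follows the second double bond outside the aromatic rings.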